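Thiazolyl amide replacing difluorophenyl: expected toxicity

A few compounds are considered here, and "the series" means these few. Any claim that something is new, unique, unknown or untested is made for them only; others in the source may bear on it.

In a toxicity assay on HepG2 cells (Homo sapiens) for inhibition, read by CellTiter-Glo, with a stated time of 48 h (on this read-out higher numbers stand for weaker inhibition and lower numbers for stronger inhibition), compound 1 `COc1ccc2nc(C)cc(OCC(=O)Nc3cccc(C)c3)c2c1` gives 39800 nM. Compound 2 `COc1cccc(NC(=O)COc2cc(C)nc3ccc(OC)cc23)c1` reaches only the limit of this assay, > 100000 nM. Compound 3 `COc1ccc2nc(C)cc(OCC(=O)Nc3cc(F)cc(F)c3)c2c1` likewise sits at the limit, > 100000 nM. The step of an at least 2.5-fold higher number from compound 1 to compound 2 (0.40 log units; beyond the scatter) and the step of an at least 2.5-fold higher number from compound 1 to compound 3 (0.40 log units; beyond the scatter) both run toward weaker inhibition, while the step that the two limits leave unreadable from compound 2 to compound 3 cannot be read because both values sit at the limit of > 100000 nM in this assay, at which 2 of the 3 values shown sit. Compound 3 therefore stands at the limit, one of two such values among the three shown.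

Compound 4 `COc1ccc2nc(C)cc(OCC(=O)Nc3nccs3)c2c1` differs from compound 3 by 1,3-thiazol-2-yl in place of 3,5-difluorophenyl on an amide-type nitrogen. Among the compounds with values here, no measured step exchanges the amide substituent for a five-membered ring, so the two steps from compound 1 are only a loose guide; both replaced 3-methylphenyl and both lifted the number beyond the scatter. Compound 4 is expected to stay at or near the limit, at 100000 nM, between 40000 nM and 300000 nM. For compound 4 the expected step is a number no higher from compound 3 to compound 4 (the limit leaves the size open), within the scatter.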

Compound 4, half-maximal inhibitory concentration: > 100000 nM
Compound 4 gave a limit, no number (the forecaster's own chance of this, stated with the estimate: 65%); the middle value lies on the limit itself.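

In this assay the change to 1,3-thiazol-2-yl on the amide-type nitrogen gives an at least 2.5-fold higher number from compound 1 to compound 4 (0.40 log units; beyond the scatter) and so runs the same way as the two earlier replacements of 3-methylphenyl. The shift toward weaker inhibition is therefore not confined to substituted phenyl groups; a five-membered aromatic ring with 2 hetero atoms shows it too. The steps among compound 2, compound 3 and compound 4 cannot be read, and only compound 1 gives a number: the limit of > 100000 nM in this assay, at which 3 of the 4 values shown sit.

As far as these compounds go, how far these three compounds differ remains open. Also open, from the compounds shown here alone, is whether an amine or a carboxylic acid on the amide-type nitrogen's substituent would bring a readable number.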